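This account rests on a few compounds, and the source may have more. Where it says the series, first, only, none or still open, it means among the compounds named here.

Compound 1, `S=C(Nc1ccccc1)OCCc1ccccn1`: > 100000 nM (a limit)
Compound 2, `Cc1ccc(NC(=S)OCCc2ccccn2)cc1`: 75000 nM
Compound 3, `Fc1ccc(NC(=S)OCCc2ccccn2)cc1`: > 100000 nM (a limit)

All three were tested in an ADME assay on MT4 cells (Homo sapiens) for cytotoxicity, read by MTT assay; a lower number here means that less compound is tolerated, a higher number that more compound is tolerated. For compound 1 the value > 100000 nM is a limit of the assay, not a number. For compound 3 the value > 100000 nM is likewise a limit. Compound 4, `S=C(Nc1ccc(Br)cc1)OCCc1ccccn1`, differs from compound 1 in one place: bromo in place of hydrogen on an aromatic carbon. Going by the values given here, two measured steps bear on this change: an at least 1.3-fold lower number from compound 1 to compound 2 (0.12 log units; that floor lies within the scatter), and a step that the two limits leave unreadable from compound 1 to compound 3. Both start from the limit, so they reveal little, and the limit of > 100000 nM in this assay, at which 2 of the 3 values shown sit, sets the ceiling for what can be read. Compound 4 is therefore expected to show no step beyond the scatter, an at least 1.1-fold lower number from compound 1 to compound 4 (0.04 log units; that floor lies within the scatter). The estimate for compound 4 is 90000 nM, between 40000 nM and 200000 nM, with a limit rather than a number quite possible.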

Compound 4, half-maximal cytotoxic concentration: 37000 nM
Beside the measured number, compound 4's estimate is 2.4-fold (0.39 log units) above it, outside the stated range (below it).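

In this assay, going by these compounds alone, bromo at this position gives what no earlier pair showed, a step beyond the scatter: an at least 2.7-fold lower number from compound 1 to compound 4 (0.43 log units; beyond the scatter). The change from fluoro gives an at least 2.7-fold lower number from compound 3 to compound 4 (0.43 log units; beyond the scatter), and the change from methyl gives a 2.0-fold lower number from compound 2 to compound 4 (0.31 log units; beyond the scatter). Compound 4 is therefore the least tolerated of the four compounds, so the group placed here can change the reading. The compounds shown leave open whether this step is particular to bromo or also appears with chloro, trifluoromethyl or an amine at this position.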